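Chloro in place of hydrogen at a second position of the core

The compounds below may be only part of what the source reports. "The series", "measured", "known", "first", "only" and "open" are said of these compounds alone.

compound 1 `O=c1cc(CSC(=S)N2CCCC2)oc2ccccc12` gives 9100 nM in a functional assay on HEp-2 cells (Homo sapiens) for antiproliferative activity, read by MTT assay, with a stated time of 72 h; a lower number here means a stronger inhibitor, a higher number a weaker inhibitor
compound 2 `O=c1cc(CSC(=S)N2CCCC2)oc2cc(Cl)ccc12` gives > 40000 nM in this assay, a limit of the assay and not a number

Within the data shown here, compound 1 holds the only number in this assay. Compound 3 `O=c1c(Cl)c(CSC(=S)N2CCCC2)oc2ccccc12` differs from compound 1 by chloro in place of hydrogen on an aromatic carbon. Among the measured compounds shown here, the only measured step of this kind is an at least 4.3-fold higher number from compound 1 to compound 2 (0.64 log units; beyond the scatter), with the chloro on the other ring of the core. That step for compound 2 ended at the limit of > 40000 nM in this assay, at which 1 of the 2 values shown sits. With the chloro now on the oxygen-bearing ring, a step toward a higher number is expected, estimated as a 1.8-fold higher number from compound 1 to compound 3 (0.25 log units; within the scatter). Compound 3 is therefore expected near 16000 nM, between 5000 nM and 45000 nM.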

Compound 3, half-maximal inhibitory concentration: 600 nM
Compound 3: middle estimate off by 27-fold (1.43 log units), on the high side; the whole stated range lies above it.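

Chloro in place of hydrogen two atoms from the ring oxygen gives, in this assay, a 15-fold lower number from compound 1 to compound 3 (1.18 log units; beyond the scatter), so this change can lower the number as well as raise it. The same change on the other ring of the core left compound 2 at a limit of the assay and not a number: the limit of > 40000 nM in this assay, at which 1 of the 3 values shown sits. The outcome of this change therefore depends on where the chloro sits, across the two positions shown.

Going by these compounds, whether the lower number is specific to chloro remains open, as a bromo, a methyl or an amine at this position would be needed to tell. What drives the step also stays unresolved.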